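Compound 4: 3-Chlorophenyl in Place of Butyl

This account rests on a few compounds, and the source may have more. Where it says the series, first, only, none or still open, it means among the compounds named here.

Compound 3 `CCCCCN1CCC(C(=O)Nc2cc(Cl)c(N)cc2OC)CC1` carries butyl on a saturated chain carbon bound to an amine nitrogen in a ring. In a functional assay on the whole organism for antagonist activity, with Mus musculus as the target (on this read-out higher numbers stand for an effect only at larger amounts of compound and lower numbers for an effect already at smaller amounts), compound 3 gives only a limit, > 10 mg/kg. Compound 1 `COc1cc(N)c(Cl)cc1NC(=O)C1CCN(CC2CCCCCC2)CC1` likewise gives only a limit, > 10 mg/kg. Compound 2 `COc1cc(N)c(Cl)cc1NC(=O)C1CCN(Cc2ccc([N+](=O)[O-])cc2)CC1` also gives only a limit, > 4 mg/kg. Compound 3 thus stands at the limit of > 10 mg/kg in this assay, at which 2 of the 3 values shown sit. The remaining value sits at the limit of > 4 mg/kg in this assay, at which 1 of the 3 values shown sits. Compound 4 `COc1cc(N)c(Cl)cc1NC(=O)C1CCN(Cc2cccc(Cl)c2)CC1` differs from compound 3 by 3-chlorophenyl in place of butyl on a saturated chain carbon bound to an amine nitrogen in a ring. Within the data shown here, the steps bearing on this change are a step that the two limits leave unreadable from compound 1 to compound 3, a step that the two limits leave unreadable from compound 2 to compound 3 and a step that the two limits leave unreadable from compound 1 to compound 2; none is readable, so no step of any size or direction beyond the scatter can be expected in this assay. Compound 4 is therefore estimated at 10 mg/kg, between 3 mg/kg and 30 mg/kg, most likely again a limit. The expected step is a number no higher from compound 3 to compound 4 (the limit leaves the size open).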

Compound 4, dose for half-maximal effect: > 4 mg/kg
Compound 4: only a limit was reported; the forecaster's own chance of this, stated with the estimate: 70%; the middle value lies beyond the limit too.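

Among these compounds, compound 4 gives only a limit in this assay, as do compound 1, compound 2 and compound 3, so no step to compound 4 can be read. The compounds shown leave open whether 3-chlorophenyl, butyl, 4-nitrophenyl and cycloheptyl differ at all in this assay.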